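A few compounds are considered here, and "the series" means these few. Any claim that something is new, unique, unknown or untested is made for them only; others in the source may bear on it.

Two compounds of the series have numbers in a functional assay on HOP-62 cells (Homo sapiens) for inhibition, read by sulforhodamine B assay, with a stated time of 48 h, tested at 100 uM; a lower number here means a stronger effect, a higher number a weaker effect of the compound at the concentration tested. Compound 1 `O=C(Nc1cccc(-n2cc(-c3ccncc3)c(-c3cc(O)cc(Cl)c3)n2)c1)Nc1ccc(Cl)c(C(F)(F)F)c1` gives -12% there, and compound 2 `O=C(Nc1cccc(-n2cc(-c3ccncc3)c(-c3cc(O)cc(Cl)c3)n2)c1)Nc1ccc(Cl)c(Cl)c1` gives -3%. Among the measured compounds shown here, the single step measured so far, a number 9 percentage points higher from compound 1 to compound 2 (within the scatter), changes only a group on an aromatic carbon and leaves the read-out within the scatter. Compound 1 has the lowest of the two numbers, with compound 2 nearest and within the scatter of it, so no order between the two can be claimed.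

Compound 3 `COc1cc(Cl)cc(-c2nn(-c3cccc(NC(=O)Nc4ccc(Cl)c(C(F)(F)F)c4)c3)cc2-c2ccncc2)c1` differs from compound 1 by methyl in place of hydrogen on an oxygen on an aromatic ring, hydroxy to methoxy, 3-chloro-5-hydroxyphenyl to 3-chloro-5-methoxyphenyl. For the measured compounds named here, no measured step touches this oxygen, so nothing among the measured pairs bears directly on it; the only step known, on an aromatic carbon, stayed within the scatter. Going by the values given here, with no sign of sensitivity anywhere in the numbers so far, the step is expected to be a number 4 percentage points higher from compound 1 to compound 3 (within the scatter), within the scatter. Compound 3 is estimated at -8%, in the range -30% to 15%.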

Compound 3, a percentage reported as activity, at one concentration (the size of the read-out at that concentration, not a potency): -48%
Estimate against measurement, compound 3: 40 percentage points above, and the stated range ends above it.
By their numbers in this assay, from the lowest: compound 3; then compounds 1 and 2 (each within the scatter of the next).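

Methyl in place of hydrogen on an oxygen on an aromatic ring gives a number 36 percentage points lower from compound 1 to compound 3 (beyond the scatter) in this assay, which is the stronger effect at the concentration tested and the first sign that the read-out in this series responds to a structural change. Among the compounds shown here, the only earlier step, a number 9 percentage points higher from compound 1 to compound 2 (within the scatter), on an aromatic carbon, showed no such response, so this oxygen is the one place so far where a change moves the number beyond the scatter. No measurement at hand accounts for the size of this step.

The compounds shown leave open whether a longer chain on this oxygen, such as ethyl, or an amine in place of the hydroxy would go further or fall back. Also open, as far as these compounds go, is whether the same methyl step holds with chloro in place of trifluoromethyl, as in compound 2.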